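The source may report more compounds than this note shows. Statements on the series, on what has been measured and on what is new or still open speak of the compounds shown alone.

Measured in a physicochemical assay for solubility, read by LC-MS, in phosphate buffer, with a stated time of 24 h, at pH 7.4; a lower number here means a less soluble compound, a higher number a more soluble compound:
Compound 1 `O=C1CCCN1c1cnc(NCc2c(F)ccc3c2CCO3)c2cn[nH]c(=O)c12`: < 2000 nM (a limit of the assay, not a number)
Compound 2 `CC1(C)CC(=O)N(c2cnc(NCc3c(F)ccc4c3CCO4)n3cnnc23)C1`: 57000 nM
Compound 3 `Cc1ncccc1-c1cnc(NCc2c(F)ccc3c2CCO3)c2cn[nH]c(=O)c12`: < 2000 nM (a limit of the assay, not a number)

Among the measured compounds shown here, compound 2 holds the only actual number in this set, at 57000 nM. The other two results amount to the limit of < 2000 nM in this assay, at which 2 of the 3 values shown sit.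

Compound 4 `O=C(Nc1cnc(NCc2c(F)ccc3c2CCO3)n2cnnc12)c1ccccc1` keeps the core of compound 2 and changes one group, with benzamido in place of 4,4-dimethyl-2-oxopyrrolidin-1-yl on an aromatic carbon.

For the measured compounds named here, no measured step makes this change. The closest is a step that the two limits leave unreadable from compound 1 to compound 3, also a swap on an aromatic carbon, but it gives no size to carry over. Compound 3, with its aromatic 2-methylpyridin-3-yl, sits at < 2000 nM, which is a limit. Compound 1, with the non-aromatic 2-oxopyrrolidin-1-yl, sits at < 2000 nM, also a limit, and this goes against any reading by group type. The hint is therefore thin.

Going by the values given here, compound 2 at 57000 nM is the only compound with an actual number, so a step down in this assay is expected rather than a step up. The estimated step is a 6.3-fold lower number from compound 2 to compound 4 (0.80 log units; beyond the scatter). For compound 4 the estimated value is 9000 nM, with an expected range of 2000 nM to 40000 nM.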

Compound 4, solubility: 2000 nM
Compound 4: middle estimate off by 4.5-fold (0.65 log units), on the high side; the range from low to high includes it.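

On the core shared by compound 2 and compound 4, this assay gives a readable step at this aromatic carbon, a 29-fold lower number from compound 2 to compound 4 (1.45 log units; beyond the scatter), so the group held here makes a clear difference to the read-out. Among the compounds shown here, the one earlier step, on a different core, could not be read, whereas this pair ties a large change to one defined swap: benzamido, with its six-membered aromatic ring of carbon only and a hydrogen-bond donor, in place of 4,4-dimethyl-2-oxopyrrolidin-1-yl, with its five-membered non-aromatic ring. The number for compound 4 also falls at the same figure as the limit that applies to two other compounds, so it stands at the edge of what these results can separate: the limit of < 2000 nM in this assay, at which 2 of the 4 values shown sit.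

From the compounds shown here alone, this single pair does not separate the aromatic ring from the amide hydrogen or from the loss of the five-membered ring, so which of these differences goes with the step remains open. Going by these compounds, how an acetamido group, a morpholine or a carboxylic acid on this same aromatic carbon would read in this assay is also open, as is whether the step would carry over to the core of compound 1.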